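The source may hold more compounds than are shown below. What is called first, only, known or untested is meant among the compounds shown, and "the series" means these compounds.

Measured compounds and their numbers in a functional assay on CHO cells for agonist activity at Glucose-dependent insulinotropic receptor (Homo sapiens), read by a luciferase reporter and cAMP accumulation, with a stated time of 2 h; a lower number here means that less compound is needed, a higher number that more compound is needed for the effect:
compound 1 `CC(COC(=O)N1CCc2cc(S(C)(=O)=O)ccc21)C1CCN(C(=O)OC(C)(C)C)CC1` gives 8.4 nM
compound 2 `CC(C)(C)OC(=O)N1CCC(CCOC(=O)N2CCc3cc(S(C)(=O)=O)cc(F)c32)CC1` gives 25 nM
compound 3 `CC(COC(=O)N1CCc2cc(S(C)(=O)=O)cc(F)c21)C1CCN(C(=O)OC(C)(C)C)CC1` gives 6.8 nM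

Compound 3 carries the lowest number of the three. The step of a 1.2-fold lower number from compound 1 to compound 3 (0.09 log units; within the scatter) lies within the scatter, so compounds 1 and 3 cannot be ordered; the step of a 3.7-fold lower number from compound 2 to compound 3 (0.57 log units; beyond the scatter) is a modest one beyond the scatter.

Compound 4 `CCc1cnc(N2CCC(C(C)COC(=O)N3CCc4cc(S(C)(=O)=O)cc(F)c43)CC2)nc1` differs from compound 3 in one place: 5-ethylpyrimidin-2-yl in place of tert-butoxycarbonyl on an amine nitrogen in a ring. Neither measured step touches this position: one concerns a fluoro on an aromatic carbon, the other a methyl on a saturated chain carbon, and the tert-butoxycarbonyl group is common to all three measured compounds. Among the compounds with values here, no measured step therefore bears directly on the change, and the series gives no guide to its direction. In the absence of such a guide, the step is expected to be small, a 1.4-fold lower number from compound 3 to compound 4 (0.13 log units; within the scatter), with the direction open. Compound 4 is expected at 5 nM in this assay, with a range from 1.5 nM to 20 nM.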

Compound 4, half-maximal effective concentration in the Glucose-dependent insulinotropic receptor assay: 3.9 nM
Estimate against measurement, compound 4: 1.3-fold (0.11 log units) above; the range from low to high includes it.
By their numbers in the Glucose-dependent insulinotropic receptor assay, from the lowest: compounds 4, 3 and 1 (each within the scatter of the next, the first and the last beyond it); then compound 2.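

Within the data shown here, in the Glucose-dependent insulinotropic receptor assay compound 3 gives 6.8 nM and compound 4 gives 3.9 nM; the first change at this amine nitrogen, until now fixed as tert-butoxycarbonyl in every compound, gives a 1.7-fold lower number from compound 3 to compound 4 (0.24 log units; within the scatter), so the position takes a six-membered aromatic ring with 2 hetero atoms and compounds 3 and 4 cannot be ordered. In a physicochemical assay for lipophilicity, read by HPLC, measured as octanol-water partition, at pH 7.4 (on this read-out higher numbers stand for higher lipophilicity and lower numbers for lower lipophilicity), compound 3 gives 3.3 and compound 4 gives 3.6; the same change gives a number 0.30 log units higher from compound 3 to compound 4 (within the scatter), so this read-out does not separate the two compounds either. No available evidence accounts for these results.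

Open, on these data alone, is what a nitrile, a chloro group or a longer chain in place of the ethyl on the pyrimidine ring would give, and what an amide or urea on the same nitrogen would give. Also open, as far as these compounds go, is whether the fluoro and methyl steps seen with tert-butoxycarbonyl carry over to compounds bearing 5-ethylpyrimidin-2-yl.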